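This account rests on a few compounds, and the source may have more. Where it says the series, first, only, none or still open, it means among the compounds named here.

Measured so far:
Compound 1 `CNC(=O)CCCCCCCn1nc(-c2ccc3oc(N)nc3c2)c2c(N)ncnc21`, which in a functional assay on A549 cells (Homo sapiens) for inhibition, read by MTT assay, with a stated time of 72 h (a lower number here means a stronger inhibitor, a higher number a weaker inhibitor), gives 8360 nM.
Compound 2 `Nc1ncnc2c1c(-c1cnc3[nH]ccc3c1)nn2CCCCCC(=O)NO`, for which this assay reports only a limit, > 150000 nM.

For the measured compounds named here, compound 1 stands as the only compound with a real number in this assay; the other value shown is a limit (the limit of > 150000 nM in this assay, at which 1 of the 2 values shown sits). Compound 3 `Nc1nc2cc(-c3nn(CCCCCCCCC(=O)NO)c4ncnc(N)c34)ccc2o1` has not yet been measured. It differs from compound 1 in one place: (hydroxycarbamoyl)methyl in place of methylcarbamoyl on a saturated chain carbon, seven bonds along the chain from an aromatic nitrogen. Cut one bond further out, the same change reads 2-(methylcarbamoyl)ethyl to 3-(hydroxycarbamoyl)propyl. Going by the values given here, no step between two measured compounds of this kind is available, so the size of such a change cannot be read from the data. Compound 2 carries a hydroxycarbamoyl end on a different core, and its result is a limit rather than a number, which gives no guide for the core of compound 1. For compound 3 the expected step toward stronger inhibition is estimated as a 2.1-fold lower number from compound 1 to compound 3 (0.32 log units; beyond the scatter). Compound 3 is estimated at 4000 nM, with a range from 700 nM to 25000 nM.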

Compound 3, half-maximal inhibitory concentration: 13200 nM
The estimate for compound 3 lay 3.3-fold (0.52 log units) below the measured number, within the range that was stated.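

In this assay, for the compounds shown here, the first step that can be read at this place is a 1.6-fold higher number from compound 1 to compound 3 (0.20 log units; within the scatter) and so shows that replacing methylcarbamoyl with (hydroxycarbamoyl)methyl, on a saturated chain carbon seven bonds along the chain from an aromatic nitrogen, moves the result no further than repeat measurements of the same compound would. On the core of compound 1, the two chain ends therefore cannot be told apart by this assay even though the entering group is the larger of the two, with one more oxygen and one more hydrogen-bond donor and acceptor. No measurement shown here speaks to why the two compounds read alike.

Going by these compounds alone, only this one pair speaks to the chain end, so it remains open whether the same replacement would read alike on a different core or on a chain of another length. As far as these compounds go, it is also open whether a carboxylic acid or a primary amine at the end of this chain would move the number beyond the usual scatter, in either direction, or would likewise leave it in place.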